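This account rests on a few compounds, and the source may have more. Where it says the series, first, only, none or still open, it means among the compounds named here.

Among the measured compounds shown here, compound 2 `O=C1C(Cc2n[nH]c3ccccc23)C(=O)N(c2ccccc2)C=CN1CC(=O)N1CCCCc2ccccc21` stands at the highest number of the two measured so far in a functional assay on CHO cells for agonist activity at Melanocortin receptor 4 (Homo sapiens), read by a luciferase reporter, with a stated time of 4 h (on this read-out lower numbers stand for an effect already at smaller amounts and higher numbers for an effect only at larger amounts of compound), giving 324 nM. Compound 1 `O=C1[C@@H](Cc2n[nH]c3ccccc23)C(=O)N(c2ccccc2)C=CN1CC(=O)N1CCCCc2ccccc21` gives 100 nM. The step to compound 3 `O=C1[C@H](Cc2n[nH]c3ccccc23)C(=O)N(c2ccccc2)C=CN1CC(=O)N1CCCCc2ccccc21` is the two compounds have the same atoms and bonds; at least one stereo element is drawn with a configuration in one of them and without one in the other: 1 of 1 stereo elements differ; a stereocentre at a saturated ring carbon is drawn without a configuration in compound 2 and S in compound 3. For the measured compounds named here, one measured step bears on it: a 3.2-fold higher number from compound 1 to compound 2 (0.51 log units; beyond the scatter), read together with the fact that one of compounds 1 and 2 is drawn with a defined configuration and the other without, at the place where they differ. Going by the values given here, since the mixture already sits at a higher number than the single drawn configuration of compound 1, the other drawn configuration in compound 3 is expected to move further in the same direction, a step of a 9.3-fold higher number from compound 2 to compound 3 (0.97 log units; beyond the scatter) in this assay. Compound 3 is therefore estimated at 3000 nM, with a range from 800 nM to 20000 nM.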

Compound 3, half-maximal effective concentration: 794 nM
The estimate for compound 3 lay 3.8-fold (0.58 log units) above the measured number, and the stated range ends above it.
By their numbers in this assay, from the lowest: compound 1; then compound 2; then compound 3.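

In this assay the drawn configuration at this saturated ring carbon is now seen to matter on its own, with a 7.9-fold higher number from compound 1 to compound 3 (0.90 log units; beyond the scatter) and nothing else changed: the fact that compounds 1 and 3 differ only in the configuration as drawn. Compound 2, drawn without a configuration, has a number inside the span of the two defined forms, and the move to the S form is a 2.5-fold higher number from compound 2 to compound 3 (0.39 log units; beyond the scatter): the fact that one of compounds 2 and 3 is drawn with a defined configuration and the other without, at the place where they differ.

On these data alone, whether R would still give the lower number with an amine or a carboxylic acid added to the shared core stays open. As far as these compounds go, the maximal effect of each form also remains unknown.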